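The compounds below may be only part of what the source reports. "The series", "measured", "known", "first", "only" and "open" are said of these compounds alone.

Series notes.
Compound 1 `CC1CCN(C2CCN(S(=O)(=O)c3ccc(C(C)(C)C)cc3)CC2)CC1`: > 5000 nM
Compound 2 `Cc1noc(C)c1S(=O)(=O)N1CCC(N2CCC(C)CC2)CC1`: > 5000 nM
Compound 3 `Cc1cc(C)c(S(=O)(=O)N2CCC(N3CCC(O)CC3)CC2)c(C)c1`: 106 nM

In a functional assay on DLD-1 cells (Homo sapiens) for antiproliferative activity, read by CellTiter-Glo, with a stated time of 72 h (on this read-out lower numbers stand for stronger inhibition and higher numbers for weaker inhibition), compound 1 gives only a limit, > 5000 nM, not a number. Compound 2 likewise gives only a limit, > 5000 nM. Compound 3 gives a numbered value, 106 nM. Compound 1 thus sits at the limit of > 5000 nM in this assay, at which 2 of the 3 values shown sit, a position it shares with compound 2, while compound 3 is the one compound shown that returns a number. Compound 4 `CCCCOc1ccc(S(=O)(=O)N2CCC(N3CCC(C)CC3)CC2)cc1` differs from compound 1 in one place: butoxy in place of tert-butyl on an aromatic carbon. Compound 3 differs from compound 1 in more than one place, so its numbered value cannot be tied to the aromatic substituent alone. The step is expected to be none beyond the scatter, with compound 4 expected to stay near the limit, a step that the limit leaves unreadable from compound 1 to compound 4. Compound 4 is estimated at 6000 nM, in the range 1500 nM to 20000 nM.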

Compound 4, half-maximal inhibitory concentration: 2300 nM
Compound 4: middle estimate off by 2.6-fold (0.42 log units), on the high side; measured number inside the range.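

In this assay, butoxy in place of tert-butyl on an aromatic carbon, para to a large group, gives an at least 2.1-fold lower number from compound 1 to compound 4 (0.33 log units; beyond the scatter). Among these compounds, compound 4 is the first compound here with a numbered value that can be tied to one change, so this position does respond to its substituent. The step is only a bound, as compound 1 stands at a limit and not a number: the limit of > 5000 nM in this assay, at which 2 of the 4 values shown sit.

As far as these compounds go, whether the oxygen of butoxy or the chain carries the step stays open. A pentyl or methoxy group on that aromatic carbon would separate the two.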